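Imidazole for hydroxypiperidine on the side chain

The source may hold more compounds than are shown below. What is called first, only, known or untested is meant among the compounds shown, and "the series" means these compounds.

The measured compounds are compound 1 `O=C1c2c[n+]([O-])c3ccccc3c2C(=O)c2c1c1ccccc1n2CCCCN1CCCCC1` with 150 nM, compound 2 `CN1CCN(CCCCn2c3c(c4ccccc42)C(=O)c2c[n+]([O-])c4ccccc4c2C3=O)CC1` with 100 nM, and compound 3 `O=C1c2c[n+]([O-])c3ccccc3c2C(=O)c2c1c1ccccc1n2CCCN1CCC(O)CC1` with 190 nM, all in a functional assay on MCF7 cells (Homo sapiens) for cytotoxicity, read by MTT assay, with a stated time of 72 h; on this read-out higher numbers stand for weaker inhibition and lower numbers for stronger inhibition.

Compound 3 gives the highest of the three numbers, but its gaps to the other two are small: a 1.3-fold higher number from compound 1 to compound 3 (0.10 log units; within the scatter) and a 1.9-fold higher number from compound 2 to compound 3 (0.28 log units; within the scatter), so the three compounds cannot be told apart on these data. The unmeasured compound 4 `O=C1c2c[n+]([O-])c3ccccc3c2C(=O)c2c1c1ccccc1n2CCCCn1ccnc1` differs from compound 3 in one place: (1H-imidazol-1-yl)methyl in place of 4-hydroxypiperidin-1-yl on a saturated chain carbon, three bonds along the chain from an aromatic nitrogen.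

For the measured compounds named here, the steps that bear on this change are those that swap the terminal ring on the side chain: a 1.5-fold lower number from compound 1 to compound 2 (0.18 log units; within the scatter), a 1.3-fold higher number from compound 1 to compound 3 (0.10 log units; within the scatter) and a 1.9-fold higher number from compound 2 to compound 3 (0.28 log units; within the scatter). Each stayed within the scatter, so swapping one saturated amine ring for another left this assay almost unchanged. Going by the values given here, compound 4 instead brings an aromatic ring in place of a saturated one, and no measured step covers that, so a somewhat larger move is possible, most likely toward a higher number. The estimate for compound 4 is 280 nM, between 110 nM and 750 nM, which means an expected step of a 1.5-fold higher number from compound 3 to compound 4 (0.17 log units; within the scatter).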

Compound 4, half-maximal inhibitory concentration: 130 nM
Compound 4: the middle estimate sits 2.2-fold (0.33 log units) above what was measured, within the range that was stated.
By their numbers in this assay, from the lowest: compounds 2, 4, 1 and 3 (each within the scatter of the next).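

In this assay, compound 4 is the only one of the four with an aromatic ring at the end of the side chain, and this five-membered ring still leaves it within the scatter of the saturated rings: a 1.5-fold lower number from compound 3 to compound 4 (0.16 log units; within the scatter). Where the four-bond chain position stays the same, 1H-imidazol-1-yl replaces the saturated rings with equally small steps: a 1.2-fold lower number from compound 1 to compound 4 (0.06 log units; within the scatter) and a 1.3-fold higher number from compound 2 to compound 4 (0.11 log units; within the scatter). The position therefore accepts all four terminal groups shown, including one with no hydrogen-bond donor and one with a donor, without a difference these data can resolve.

No measurement shown here explains why these groups read alike. Still open, on these data alone, is whether a carboxylic acid, a primary amine or a phenyl ring at the end of the chain, or a longer chain, would move the number beyond the scatter.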